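The compounds below may be only part of what the source reports. "The series", "measured", "known", "first", "only" and "open" are said of these compounds alone.

Measured so far in a functional assay on NCI-H460 cells (Homo sapiens) for inhibition; a higher number here means a weaker inhibitor of growth, a lower number a stronger inhibitor of growth:
- compound 1 `COc1cc(/C=C/C(=O)c2cccc(-n3cc(-c4ccccc4)[nH]c3=O)c2)ccc1O` gives 1950 nM
- compound 2 `O=C(/C=C/c1cccc(O)c1)c1cccc(-n2cc(-c3ccc(Cl)cc3)[nH]c2=O)c1` gives 2410 nM
- compound 3 `COc1ccc(-c2cn(-c3cccc(C(=O)/C=C/c4ccc(O)c(OC)c4)c3)c(=O)[nH]2)cc1` gives 3230 nM

Compound 3 holds the highest of the three numbers, yet its gaps to compound 2 and to compound 1 both lie within the scatter, so the three read as one level.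

Compound 4 `COc1cc(/C=C/C(=O)c2cccc(-n3cc(-c4ccc(Cl)cc4)[nH]c3=O)c2)ccc1O` differs from compound 3 by chloro in place of methoxy on an aromatic carbon. Going by the values given here, no measured step covers this exchange. Among the compounds with values here, the only step, a 1.7-fold higher number from compound 1 to compound 3 (0.22 log units; within the scatter), concerns the group that now leaves and stayed within the scatter. Within the data shown here, compound 2 carries the entering chloro group but differs elsewhere, so its value shows only that a chloro analogue sits at the same level.

Hence no step beyond the scatter is expected, a 1.5-fold lower number from compound 3 to compound 4 (0.17 log units; within the scatter). Compound 4 is estimated at 2200 nM, range 900 nM to 5500 nM.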

Compound 4, concentration for 50% growth inhibition: 3900 nM
Compound 4: the middle estimate sits 1.8-fold (0.25 log units) below what was measured; measured number inside the range.
By their numbers in this assay, from the lowest: compounds 1, 2, 3 and 4 (each within the scatter of the next).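

In this assay chloro in place of methoxy, para to a large group, gives a 1.2-fold higher number from compound 3 to compound 4 (0.08 log units; within the scatter) and puts the two groups at one level at this position. Chloro in place of hydrogen at the same place gives a 2.0-fold higher number from compound 1 to compound 4 (0.30 log units; within the scatter) and 4-hydroxy-3-methoxyphenyl in place of 3-hydroxyphenyl gives a 1.6-fold higher number from compound 2 to compound 4 (0.21 log units; within the scatter) so neither change leaves the scatter. Nothing on hand offers an explanation for this flat reading.

Open, from the compounds shown here alone, is whether an amine or a carboxylic acid at this position would move the number beyond the scatter. Going by these compounds, a longer chain in place of chloro remains equally open.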